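Isopropyl in Place of Methoxy: What to Expect

This account rests on a few compounds, and the source may have more. Where it says the series, first, only, none or still open, it means among the compounds named here.

Three related compounds have been measured. Compound 1 `O=C(NCC1(c2ccccc2)CCCCC1)Nc1ccccc1` gives 2300 nM in an assay on microsomes from intestine for inhibition of acyl-CoA:cholesterol acyltransferase (Oryctolagus cuniculus); on this read-out higher numbers stand for weaker inhibition and lower numbers for stronger inhibition. Compound 2 `Cc1ccccc1NC(=O)NCC1(c2ccccc2)CCCCC1` gives 640 nM, and compound 3 `COc1ccc(NC(=O)NCC2(c3ccccc3)CCCCC2)cc1` gives 4900 nM, the highest number of the three and thus the weakest inhibitor among them. Compound 4 `CC(C)c1ccc(NC(=O)NCC2(c3ccccc3)CCCCC2)cc1` differs from compound 3 by isopropyl in place of methoxy on an aromatic carbon. Among the measured compounds shown here, two measured steps bear on this change: a 2.1-fold higher number from compound 1 to compound 3 (0.33 log units; beyond the scatter), and a 3.6-fold lower number from compound 1 to compound 2 (0.56 log units; beyond the scatter), where a carbon-only group entered the same ring. Taking the methoxy away should therefore bring the number down, and a carbon-only group in its place may lower it somewhat further. The expected step is a 3.3-fold lower number from compound 3 to compound 4 (0.51 log units; beyond the scatter). Compound 4 is estimated at 1500 nM, with a likely range from 500 nM to 4500 nM.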

Compound 4, half-maximal inhibitory concentration: 1500 nM
Compound 4: the middle estimate sits on the measured number at the digits printed; the range from low to high includes it.
By their numbers in this assay, from the lowest: compound 2; then compounds 4 and 1 (each within the scatter of the next); then compound 3.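

On this carbon, para to a large group, the identity of the group clearly counts: isopropyl in place of methoxy gives a 3.3-fold lower number from compound 3 to compound 4 (0.51 log units; beyond the scatter). Isopropyl in place of hydrogen gives only a 1.5-fold lower number from compound 1 to compound 4 (0.19 log units; within the scatter), so the bulkier carbon-only group is accepted here without a change beyond the scatter, whereas methoxy gives a 2.1-fold higher number from compound 1 to compound 3 (0.33 log units; beyond the scatter). No measurement at hand accounts for this difference between the two groups.

From the compounds shown here alone, whether an amine, a carboxylic acid or a longer chain on this same carbon would match isopropyl or methoxy remains open.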